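The source may hold more compounds than are shown below. What is called first, only, known or untested is meant among the compounds shown, and "the series" means these compounds.

Measured in an ADME assay on microsomes from liver (Homo sapiens) for metabolic stability (on this read-out lower numbers stand for slow clearance and higher numbers for fast clearance), each value a limit of the assay and not a number:
- compound 1 `Cc1ccc2[nH]c(C(=O)N[C@H]3CN(S(=O)(=O)c4ccccc4)C[C@@H]3C(=O)N[C@H]3CCCNC3)cc2c1`: < 3 mL.min-1.g-1
- compound 2 `O=C(N[C@H]1CN(S(=O)(=O)c2ccccc2)C[C@@H]1C(=O)N[C@H]1CCCNC1)c1cc(-c2ccc(Cl)cc2)on1`: < 3 mL.min-1.g-1
- compound 3 `O=C(N[C@H]1CN(S(=O)(=O)c2ccccc2)C[C@@H]1C(=O)N[C@H]1CCCNC1)c1cc(-c2ccccc2Cl)on1`: < 3 mL.min-1.g-1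

Compound 3 has no exact number, only its limit (< 3 mL.min-1.g-1). The same holds for the whole set, as shown by the limit of < 3 mL.min-1.g-1 in this assay, at which 3 of the 3 values shown sit.

Compound 4 `CC(=O)N1CCC[C@H](NC(=O)[C@H]2CN(S(=O)(=O)c3ccccc3)C[C@@H]2NC(=O)c2cc(-c3ccccc3Cl)on2)C1` is compound 3 with one change, (acetyl in place of hydrogen on an amine nitrogen in a ring). In words, this is acetyl in place of hydrogen on an amine nitrogen in a ring, turning piperidin-3-yl into 1-acetylpiperidin-3-yl.

Among the measured compounds shown here, none of the measured steps touches that nitrogen, and none has a readable size: a step that the two limits leave unreadable from compound 1 to compound 2, a step that the two limits leave unreadable from compound 1 to compound 3 and a step that the two limits leave unreadable from compound 2 to compound 3. They therefore offer no measured guide to the effect of the acetyl. With nothing to set a direction, no step beyond the scatter is expected in this assay, though this expectation is a weak one. The estimated change is a number no lower from compound 3 to compound 4 (the limit leaves the size open). For compound 4 the expected value is 3 mL.min-1.g-1, with an estimated range from 1.5 mL.min-1.g-1 to 10 mL.min-1.g-1.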

Compound 4, intrinsic clearance in microsomes: > 300 mL.min-1.g-1
Compound 4 gave a limit, no number; the forecaster's own chance of this, stated with the estimate: 60%; middle value at least 100-fold (2.00 log units) away from the limit.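

In this assay, the ring nitrogen of the piperidin-3-yl group turns out to matter a great deal: acetyl in place of its hydrogen gives an at least 100-fold higher number from compound 3 to compound 4 (2.00 log units; beyond the scatter). Among the compounds shown here, the earlier compounds differ only in the group on the carbonyl at the other end of the molecule, and their steps cannot be read, so this is the first readable change in the set. Compound 4 has a limit of the assay and not a number, so the full size of the step stays open: the limit of > 300 mL.min-1.g-1 in this assay, at which 1 of the 4 values shown sits.

The compounds shown leave open whether this large step belongs to acetyl alone or would also come with another group on that nitrogen, such as methyl or a longer acyl chain. They also leave open whether acetyl there would act the same way with the groups carried by compound 1 and compound 2.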